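The source may report more compounds than this note shows. Statements on the series, on what has been measured and on what is new or still open speak of the compounds shown alone.

Among the compounds with values here, compound 1, `COc1cc(C2=NOC(c3c[nH]c4ccccc34)C2)cc(OC)c1OC`, is the lower of the two numbers measured so far in a functional assay on LNCaP C4-2 cells (Homo sapiens) for inhibition, read by MTT assay, with a stated time of 48 h; on this read-out higher numbers stand for weaker inhibition and lower numbers for stronger inhibition. In this assay compound 1 gives 5000 nM, while its nearest neighbour, compound 2, `COc1ccc(C2=NOC(c3c[nH]c4ccccc34)C2)cc1OC`, gives 65500 nM. Within the data shown here, the one step that can be measured between them, a 13-fold higher number from compound 1 to compound 2 (1.12 log units; beyond the scatter), comes from a change on the methoxy-bearing ring of the shared core, not on the indole side.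

Compound 3, `COc1ccc2[nH]cc(C3CC(c4cc(OC)c(OC)c(OC)c4)=NO3)c2c1`, differs from compound 1 by methoxy in place of hydrogen on an aromatic carbon. Among the measured compounds shown here, no measured step touches this ring, so the change from compound 1 to compound 2 offers no direct guide to it: the single measured step concerns a different ring and a removal rather than an addition. On the numbers shown, no step beyond the scatter is expected from compound 1 to compound 3 in this assay, in either direction, though the range given is kept wide because no comparable step has been measured; the step that the estimate implies is a 1.3-fold lower number from compound 1 to compound 3 (0.10 log units; within the scatter). Compound 3 is therefore estimated at 4000 nM, with a range from 1000 nM to 20000 nM.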

Compound 3, half-maximal inhibitory concentration: 71200 nM
Compound 3: the middle estimate sits 18-fold (1.25 log units) below what was measured, and the stated range ends below it.
By their numbers in this assay, from the lowest: compound 1; then compounds 2 and 3 (each within the scatter of the next).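

Adding a methoxy on this aromatic carbon, meta to a fused ring and para to a fused ring, is not a neutral change in this assay: the result is a 14-fold higher number from compound 1 to compound 3 (1.15 log units; beyond the scatter) and so shows that this position responds to substitution. Within the data shown here, until now, the only measured step was a 13-fold higher number from compound 1 to compound 2 (1.12 log units; beyond the scatter) on the methoxy-bearing ring, which left open whether the other side of the shared core would respond at all. Across these three compounds, both changes from compound 1 give higher numbers, one removing a methoxy and the other adding one, so neither change improves on compound 1 in this assay. Nothing available here accounts for the size of the new step.

On these data alone, it remains open whether the higher number belongs to methoxy specifically or would also follow from a fluorine atom, a hydroxyl or a methyl group on the same aromatic carbon. Also open, as far as these compounds go, is whether a methoxy on another carbon of that six-membered ring would give a similar result.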